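This account rests on a few compounds, and the source may have more. Where it says the series, first, only, none or still open, it means among the compounds named here.

Measured compounds in a functional assay on HeLa cells (Homo sapiens) for inhibition, read by sulforhodamine B assay; on this read-out lower numbers stand for stronger inhibition and higher numbers for weaker inhibition:
compound 1 `Cc1ccc(NC2=CC(=O)c3nc4n(c3C2=O)[C@H]2OC[C@@H](O)[C@H]2OC4)cc1C` — 2690 nM
compound 2 `O=C1C(Nc2cccc(Cl)c2)=CC(=O)c2c1nc1n2[C@H]2OC[C@@H](O)[C@H]2OC1` — 7970 nM
compound 3 `O=C1C(NC2CCCC2)=CC(=O)c2c1nc1n2[C@H]2OC[C@@H](O)[C@H]2OC1` — reaches a limit of the assay, > 16000 nM

Compound 1 gives the lowest of the two numbers shown; compound 2 gives a higher number, and that gap lies beyond the scatter. The value of compound 3 is a limit and not a number.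

Compound 4 `O=C1C=C(N2CCCCC2)C(=O)c2c1nc1n2[C@H]2OC[C@@H](O)[C@H]2OC1` has not yet been measured in this assay. It differs from compound 1 in one place: piperidin-1-yl in place of (3,4-dimethylphenyl)amino on a double-bonded ring carbon. For the measured compounds named here, one measured step bears on this kind of change, an at least 2.0-fold higher number from compound 2 to compound 3 (0.30 log units; that floor lies within the scatter); there an aromatic ring on the amine nitrogen gave way to a saturated ring, and the number rose to the limit (the limit of > 16000 nM in this assay, at which 1 of the 3 values shown sits). The change to compound 4 likewise removes the aromatic ring, and also the hydrogen on the nitrogen. A higher number in this assay is therefore expected, of at least the size of that step and possibly larger.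

For compound 4 the estimate is 12000 nM, within 4000 nM to 40000 nM, which means an expected step of a 4.5-fold higher number from compound 1 to compound 4 (0.65 log units; beyond the scatter).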

Compound 4, half-maximal inhibitory concentration: > 16000 nM
Compound 4: no number, only a limit; the forecaster's own chance of this, stated with the estimate: 40%; middle value at least 1.3-fold (0.12 log units) away from the limit.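

Replacing (3,4-dimethylphenyl)amino with piperidin-1-yl on the double-bonded ring carbon gives an at least 5.9-fold higher number from compound 1 to compound 4 (0.77 log units; beyond the scatter) in this assay, so at this position the change from an aromatic ring to a saturated ring now shows a step beyond the scatter, which the floor of an at least 2.0-fold higher number from compound 2 to compound 3 (0.30 log units; that floor lies within the scatter) could not show. Compound 4 gives > 16000 nM, which is a limit and not a number, so this step too is only a floor. Among the compounds shown, both saturated-ring compounds, compound 3 and compound 4, now sit at the same limit, while both aromatic compounds give numbers: the limit of > 16000 nM in this assay, at which 2 of the 4 values shown sit.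

Compound 4 loses the aromatic ring and the hydrogen on the nitrogen at once, and the compounds shown do not separate these two changes. On these data alone, how a methyl(phenyl)amino or a benzylamino group would read on this carbon remains open.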